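Adding a Methoxy Group: Expected Effect on Plasma Protein Binding

The source may hold more compounds than are shown below. What is called first, only, known or untested is meant among the compounds shown, and "the series" means these compounds.

Compound 1, `CCc1nc2nc(C)cc(Nc3ccc(C(F)(F)F)cc3)n2n1`: 87.5%
Compound 2, `CCc1nc2nc(C)cc(Nc3ccc(Cl)cc3)n2n1`: 86.1%

Of the compounds shown here, two sharing the same core have been measured in an ADME assay on a cell-free system (plasma, Homo sapiens) for protein binding. Compound 1 gives 87.5%, and compound 2 gives 86.1%. Among the compounds with values here, of these two values of the unbound fraction, compound 1 has the lower one, and the only measured step, a 1.1-fold higher unbound fraction from compound 1 to compound 2 (0.05 log units; within the scatter), concerns a change on the aromatic ring rather than on the ethyl chain.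

The next compound, compound 3, `COCCc1nc2nc(C)cc(Nc3ccc(C(F)(F)F)cc3)n2n1`, differs from compound 1 in a single place: methoxy in place of hydrogen on a saturated chain carbon, two bonds along the chain from an aromatic carbon. Within the data shown here, no measured pair shows this change, so nothing in this assay speaks directly to it; the single known step only shows that the ring substitution did not move the binding beyond the scatter.

With no guidance from the data, the expectation is a step that stays within the scatter, so that compound 3 is estimated at 84%, with a range from 74% to 91%. Expressed as a step, this means an expected a 1.3-fold higher unbound fraction from compound 1 to compound 3 (0.11 log units; within the scatter).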

Compound 3, plasma protein binding: 73.7%
Estimate against measurement, compound 3: 1.6-fold (0.22 log units) (unbound fraction) below; the whole stated range lies above it.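

In this assay, the ethyl chain turns out to be a place where a small addition registers: going from ethyl to 2-methoxyethyl gives a 2.1-fold higher unbound fraction from compound 1 to compound 3 (0.32 log units; beyond the scatter) as a modest step, but one that lies beyond the scatter. The earlier change on the aromatic ring, from trifluoromethyl to chloro, gave a 1.1-fold higher unbound fraction from compound 1 to compound 2 (0.05 log units; within the scatter) and stayed within the scatter, so this is the first change among the compounds shown that clearly alters how much compound remains free. It rests on a single pair of compounds, and nothing at hand explains why the methoxy group has this effect.

The compounds shown leave open whether the oxygen matters or whether the extra chain length alone would do the same, a question that a plain propyl or butyl chain could answer, as could a hydroxyl or an amine in place of the methoxy. Also open, from the compounds shown here alone, is whether the same addition would give a step of similar size with chloro on the ring, as in compound 2.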